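Solubility of Two Urea Pairs, Pyrrole for Oxane

The compounds below may be only part of what the source reports. "The series", "measured", "known", "first", "only" and "open" are said of these compounds alone.

Measured compounds:
Compound 1, `O=C(Nc1ccc(C(F)(F)F)cc1)NC1CCN(C(=O)C2CCCOC2)CC1`, gives 25 ug/mL in a physicochemical assay for solubility, read by mass spectrometry, in phosphate buffer, with a stated time of 24 h, at pH 3; a lower number here means a less soluble compound, a higher number a more soluble compound.
Compound 2, `O=C(Nc1ccc(C(F)(F)F)cc1)NC1CCN(C(=O)c2cc[nH]c2)CC1`, gives 13 ug/mL in this assay.
Compound 3, `O=C(Nc1ccc(OC(F)(F)F)cc1)NC1CCN(C(=O)C2CCCOC2)CC1`, gives 868 ug/mL in this assay.

Compound 1 and compound 2 share a core and differ in one place, (1H-pyrrol-3-yl in place of oxan-3-yl on a carbonyl carbon). That change gave a 1.9-fold lower number from compound 1 to compound 2 (0.28 log units; within the scatter), so the two values are not separated here. Compound 3 differs from compound 1 in a different place, (trifluoromethoxy in place of trifluoromethyl on an aromatic carbon), and that change gave a 35-fold higher number from compound 1 to compound 3 (1.54 log units; beyond the scatter). Compound 3 stands well apart from both compound 1 and compound 2 in this assay.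

Compound 4, `O=C(Nc1ccc(OC(F)(F)F)cc1)NC1CCN(C(=O)c2cc[nH]c2)CC1`, is not yet measured. It differs from compound 3 by 1H-pyrrol-3-yl in place of oxan-3-yl on a carbonyl carbon. For the measured compounds named here, this is the same change as the one from compound 1 to compound 2, on the same kind of carbonyl carbon with the same ring neighbour, but it is now made on the core of compound 3 rather than the core of compound 1; how those two cores differ is told by trifluoromethoxy in place of trifluoromethyl on an aromatic carbon.

Because a 1.9-fold lower number from compound 1 to compound 2 (0.28 log units; within the scatter) stayed within the scatter, compound 4 is expected to land close to compound 3, with an expected step of a 1.9-fold lower number from compound 3 to compound 4 (0.29 log units; within the scatter). Going by the values given here, compound 4 is therefore estimated at 450 ug/mL in this assay, with a range from 150 ug/mL to 1300 ug/mL, the width reflecting that only one earlier pair shows this change.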

Compound 4, solubility: 58 ug/mL
Compound 4: the middle estimate sits 7.8-fold (0.89 log units) above what was measured, and the stated range ends above it.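

In this assay, replacing oxan-3-yl with 1H-pyrrol-3-yl on the carbonyl carbon gave a 15-fold lower number from compound 3 to compound 4 (1.18 log units; beyond the scatter) on the trifluoromethoxy core, whereas the same replacement gave a 1.9-fold lower number from compound 1 to compound 2 (0.28 log units; within the scatter) on the trifluoromethyl core, so the size of this step did not carry from one core to the other. Seen from the other side of the same four compounds, trifluoromethoxy in place of trifluoromethyl gave a 35-fold higher number from compound 1 to compound 3 (1.54 log units; beyond the scatter) with oxan-3-yl present, but a 4.5-fold higher number from compound 2 to compound 4 (0.65 log units; beyond the scatter) with 1H-pyrrol-3-yl present, so the two changes do not simply add up and the effect of each depends on the other. For the compounds shown here, this single set of four compounds shows only that a step could not be copied between these two cores; it does not show how the step would behave on any other core, and nothing measured here bears on why the cores differ.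

Going by these compounds, it remains open whether a longer carbon chain, or a ring carrying an amine or a carboxylic acid, in place of oxan-3-yl would depend on the core in the same way. On these data alone, it is also open whether a nitrile or a chlorine in place of trifluoromethoxy on the aromatic carbon would show this dependence on the group at the carbonyl.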